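The compounds below may be only part of what the source reports. "The series", "measured", "known", "first", "only" and "open" are said of these compounds alone.

Working notes on the series. The shared core carries its variable group on a saturated chain carbon, two bonds along the chain from a saturated ring carbon. For the measured compounds named here, compound 1 `NC1(CCn2cc(F)c(=O)[nH]c2=O)OC(=O)C(OCc2ccccc2)=C1OCc1ccccc1` supplies the only read number: in an ADME assay on WI-38 cells (Homo sapiens) for inhibition, read by MTT assay, with a stated time of 72 h (on this read-out higher numbers stand for weaker inhibition and lower numbers for stronger inhibition), compound 1 gives 36200 nM. Compound 2 `Nc1ncn(CCC2(N)OC(=O)C(OCc3ccccc3)=C2OCc2ccccc2)c(=O)n1` reaches only a limit of this assay, > 100000 nM. Compound 3 `NC1(CCn2ncc(=O)[nH]c2=O)OC(=O)C(OCc2ccccc2)=C1OCc1ccccc1` likewise stands at a limit of this assay, > 100000 nM, so its position on the numbers shown is known only as a bound; (the limit of > 100000 nM in this assay, at which 2 of the 3 values shown sit). Both steps away from compound 1 are open-ended, an at least 2.7-fold higher number from compound 1 to compound 2 (0.44 log units; beyond the scatter) and an at least 2.7-fold higher number from compound 1 to compound 3 (0.44 log units; beyond the scatter), and between the two limits a step that the two limits leave unreadable from compound 2 to compound 3.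

Compound 4 `Cc1cn(CCC2(N)OC(=O)C(OCc3ccccc3)=C2OCc2ccccc2)c(=O)[nH]c1=O` is the next step from compound 3: a group of 9 heavy atoms (5 carbon, 2 nitrogen, 2 oxygen; one six-membered aromatic ring with 2 hetero atoms) in place of a group of 8 heavy atoms (3 carbon, 3 nitrogen, 2 oxygen; one six-membered aromatic ring with 3 hetero atoms), on a saturated chain carbon, two bonds along the chain from a saturated ring carbon. The ring entering has 2 hetero atoms, as in compound 1, while the ring leaving has 3, as in compound 3 and compound 2. The measured step that bears on this move is an at least 2.7-fold higher number from compound 1 to compound 3 (0.44 log units; beyond the scatter), which runs the opposite way and has only a lower bound to its size. Returning to a ring with 2 hetero atoms is therefore expected to bring the number back down toward that of compound 1, with a real chance that this assay again reports only a limit. Compound 4 is expected at 50000 nM, within 20000 nM to 100000 nM, which would mean an at least 2.0-fold lower number from compound 3 to compound 4 (0.30 log units; that floor lies within the scatter).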

Compound 4, half-maximal inhibitory concentration: > 100000 nM
Compound 4: no number, only a limit; the forecaster's own chance of this, stated with the estimate: 35%; middle value at least 2.0-fold (0.30 log units) from the limit.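

Methyl in place of fluoro on an aromatic carbon keeps the ring with 2 hetero atoms and still gives an at least 2.7-fold higher number from compound 1 to compound 4 (0.44 log units; beyond the scatter), so in this assay a ring of that kind does not by itself yield a read number. This is the first step in the series that changes only the substituent on that ring, and it shows that the number is sensitive to this single exchange, with fluoro in compound 1 the only group shown that gives a read value. The steps to compound 4 from compound 2 and from compound 3 cannot be read, and the series now rests on a single number set against limits: the limit of > 100000 nM in this assay, at which 3 of the 4 values shown sit.

As far as these compounds go, how far compound 2, compound 3 and compound 4 lie from compound 1, and how they order among themselves, stays open. From the compounds shown here alone, whether the read value is specific to fluoro also stays open: a chloro group or a plain hydrogen on that aromatic carbon would bear on this, as would a longer chain in place of the present one with fluoro retained.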